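The source may hold more compounds than are shown below. What is called first, only, known or untested is meant among the compounds shown, and "the series" means these compounds.

Of the compounds shown here, three have been measured in a functional assay with platelet-activating factor receptor (Cavia porcellus) as the target; on this read-out higher numbers stand for an effect only at larger amounts of compound and lower numbers for an effect already at smaller amounts. Compound 1, with the structure `COc1ccc(C(=C/C=C/C(=O)Nc2ccc(-c3cccnc3)cc2)c2ccc(OC)cc2)cc1`, gives 0.15 mg/kg. Compound 2, with the structure `CCCCCCCC/C(=C\C=C\C(=O)N[C@H](C)CCCc1cccnc1)c1ccc(OC)cc1`, gives 0.1 mg/kg. Compound 3, with the structure `COc1ccc(C(=C/C=C/C(=O)N[C@H](C)CCCc2cccnc2)c2ccc(OC)c(OC)c2)cc1OC`, gives 0.14 mg/kg. The number for compound 2 is the lowest of the three as written, but its gaps to compound 3 and to compound 1 both lie within the usual scatter of repeated measurements, so the three compounds cannot be told apart on these numbers.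

The unmeasured compound 4 has the structure `COc1ccc(/C(=C/C=C/C(=O)N[C@H](C)CCCc2cccnc2)C(C)C)cc1`. Compared with compound 2, the change is isopropyl in place of octyl on a double-bonded chain carbon bound to an aromatic carbon and a double-bonded chain carbon. Among the measured compounds shown here, no measured pair shows a change of this kind, so there is no step to rest on. Since compounds 1, 2 and 3 carry different groups at this position yet give numbers within the scatter of one another, a step from compound 2 to compound 4 in this assay of a 2.0-fold higher number from compound 2 to compound 4 (0.30 log units; within the scatter) is expected, that is, no clear shift beyond the scatter. For compound 4 the estimated value in this assay is 0.2 mg/kg, with a likely range from 0.07 mg/kg to 0.6 mg/kg.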

Compound 4, dose for 50% inhibition: 0.41 mg/kg
Beside the measured number, compound 4's estimate is 2.1-fold (0.31 log units) below it, within the range that was stated.
By their numbers in this assay, from the lowest: compounds 2, 3 and 1 (each within the scatter of the next); then compound 4.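

The step shows that this position is not indifferent to the group it carries: in this assay, isopropyl in place of octyl gives a 4.1-fold higher number from compound 2 to compound 4 (0.61 log units; beyond the scatter), so more compound is needed for the same effect. Compounds 1, 2 and 3 differ from one another in more than one place, so their closely spaced numbers could not show this; a single change at this carbon now does, and it clearly favours octyl over isopropyl here. Nothing available explains why the shorter group needs the larger dose.

As far as these compounds go, with only these two chains to compare, it remains open whether the number rises gradually or abruptly as the chain shortens, which a butyl or hexyl chain could help settle. From the compounds shown here alone, whether a chain ending in an amine or a carboxylic acid would be tolerated at this carbon also remains open.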